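Swapping the Sulfonyl Nitrogen Group for an Alkoxy Chain

A few compounds are considered here, and "the series" means these few. Any claim that something is new, unique, unknown or untested is made for them only; others in the source may bear on it.

Three compounds share a core in which a urea is joined to a sulfonyl group, and they differ only in what sits on the sulfonyl sulfur. Compound 1 `C=CCN(CC)S(=O)(=O)NC(=O)Nc1c(C(C)C)cccc1C(C)C` gives 2100 nM in an assay on liver for inhibition of sterol O-acyltransferase 1 (Rattus norvegicus), using microsomes; on this read-out higher numbers stand for weaker inhibition and lower numbers for stronger inhibition. Compound 2 `CCCCN(CC)S(=O)(=O)NC(=O)Nc1c(C(C)C)cccc1C(C)C` gives 1200 nM in this assay, and the change a 1.8-fold lower number from compound 1 to compound 2 (0.24 log units; within the scatter) stays within the scatter. Compound 3 `CC(C)c1cccc(C(C)C)c1NC(=O)NS(=O)(=O)N(C(C)C)C(C)(C)C` gives 140 nM and stands lowest of the three, with a 15-fold lower number from compound 1 to compound 3 (1.18 log units; beyond the scatter) and an 8.6-fold lower number from compound 2 to compound 3 (0.93 log units; beyond the scatter) both beyond the scatter.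

Compound 4 `CCCCCCC(C)OS(=O)(=O)NC(=O)Nc1c(C(C)C)cccc1C(C)C` is not yet measured. It differs from compound 3 by (1-methylheptyl)oxy in place of isopropyl(tert-butyl)amino on a sulfonyl sulfur. Among the compounds with values here, no measured step trades a nitrogen-linked group on the sulfonyl sulfur for an oxygen-linked one, so nothing directly bears on this change. What the measured steps do show is that the group on the sulfonyl sulfur matters: the two changes into compound 3 each moved the number beyond the scatter. Since compound 3 is the lowest point, a move away from it more likely rises than falls. Compound 4 is therefore expected to give roughly 1000 nM in this assay, within 200 nM to 5000 nM, an expected step of a 7.1-fold higher number from compound 3 to compound 4 (0.85 log units; beyond the scatter).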

Compound 4, half-maximal inhibitory concentration: 35000 nM
Beside the measured number, compound 4's estimate is 35-fold (1.54 log units) below it; measured number outside the range, above it.
By their numbers in this assay, from the lowest: compound 3; then compounds 2 and 1 (each within the scatter of the next); then compound 4.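

In this assay, within the data shown here, trading the nitrogen-linked group on the sulfonyl sulfur for (1-methylheptyl)oxy gives a 250-fold higher number from compound 3 to compound 4 (2.40 log units; beyond the scatter), a step well beyond any among the earlier compounds, and the first to show that a change at this position can push the number sharply upward. The other two comparisons point the same way, with a 29-fold higher number from compound 2 to compound 4 (1.46 log units; beyond the scatter) and a 17-fold higher number from compound 1 to compound 4 (1.22 log units; beyond the scatter), so compound 4 is the weakest inhibitor of the four, and all three nitrogen-linked groups, however different, give stronger inhibition than this one oxygen-linked group. No measurement here explains why the number rises so far.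

The change in compound 4 alters both the atom attached to the sulfur and the chain it carries, so the compounds shown cannot tell which of the two drives the rise. A (1-methylheptyl)amino group would keep the chain on a nitrogen, and an isopropoxy or tert-butoxy group would put the branched groups of compound 3 on an oxygen, so either could begin to separate the two.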